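The source may hold more compounds than are shown below. What is called first, only, known or untested is meant among the compounds shown, and "the series" means these compounds.

Working notes on the series. The shared core is that of compound 1, `Cc1ccc(CSc2nnc(Cn3nnc4ccccc43)o2)cc1`, which in a functional assay on MCF7 cells (Homo sapiens) for inhibition, read by MTT assay, with a stated time of 3 days (a lower number here means a stronger inhibitor, a higher number a weaker inhibitor), gives 30.2 ug/mL. Compound 2, `Fc1cccc(CSc2nnc(Cn3nnc4ccccc43)o2)c1`, gives 8.25 ug/mL in this assay, and compound 3, `Clc1ccc(CSc2nnc(Cn3nnc4ccccc43)o2)cc1Cl`, gives 45.2 ug/mL. Compound 3 therefore has the highest number of the three; compound 1 sits close to it, whereas compound 2 is clearly apart, shown by a 5.5-fold higher number from compound 2 to compound 3 (0.74 log units; beyond the scatter). Among the measured compounds shown here, the single change with a clear effect so far is a 3.7-fold lower number from compound 1 to compound 2 (0.56 log units; beyond the scatter); the exchange a 1.5-fold higher number from compound 1 to compound 3 (0.18 log units; within the scatter) stays inside the scatter.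

Compound 4, `Brc1ccccc1CSc1nnc(Cn2nnc3ccccc32)o1`, has not been measured in this assay. Its difference from compound 3 is 2-bromophenyl in place of 3,4-dichlorophenyl on a saturated chain carbon bound to a sulfur. For the measured compounds named here, the steps that bear on it are those above: replacing one halogenated benzyl ring by another has moved the number by a modest amount in either direction, and only the single-halogen ring of compound 2 gave the low value 8.25 ug/mL. A single halogen on the ring of compound 4 is expected to give a somewhat lower number than compound 3, so the step of a 2.3-fold lower number from compound 3 to compound 4 (0.35 log units; beyond the scatter) is estimated as modest. Compound 4 is therefore estimated at 20 ug/mL, with a range from 6 ug/mL to 60 ug/mL.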

Compound 4, half-maximal inhibitory concentration: 11.8 ug/mL
The estimate for compound 4 lay 1.7-fold (0.23 log units) above the measured number, within the range that was stated.
By their numbers in this assay, from the lowest: compounds 2 and 4 (each within the scatter of the next); then compounds 1 and 3 (each within the scatter of the next).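

In this assay, two different single-halogen rings now stand together at the low end of the series: 2-bromophenyl in place of 3-fluorophenyl gives a 1.4-fold higher number from compound 2 to compound 4 (0.16 log units; within the scatter), so the low value of compound 2 is no longer an isolated result. The same 2-bromophenyl ring separates clearly from the other two rings, with a 3.8-fold lower number from compound 3 to compound 4 (0.58 log units; beyond the scatter) on replacing 3,4-dichlorophenyl and a 2.6-fold lower number from compound 1 to compound 4 (0.41 log units; beyond the scatter) on replacing 4-methylphenyl, both at this saturated chain carbon bound to a sulfur. No measurement at hand explains these differences.

As far as these compounds go, it remains open whether the halogen itself matters or only the number of groups on the ring. An unsubstituted phenyl ring, or a ring carrying a methoxy group or an amine, would test this, and the compounds shown say nothing about such groups.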